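The source may report more compounds than this note shows. Statements on the series, on what has been measured and on what is new or still open speak of the compounds shown alone.

Measured so far in an assay on HEK293 cells for negative allosteric modulation of metabotropic glutamate receptor 5 (Homo sapiens), read by FLIPR, with a stated time of 1 h; a lower number here means a stronger inhibitor, a higher number a weaker inhibitor:
compound 1 `O=C(C1CC1)N1CCc2nc(C#Cc3ccccc3)sc2C1` gives 290 nM
compound 2 `O=C(C1CCCCC1)N1CCc2nc(C#Cc3ccccc3)sc2C1` gives only the assay limit > 10000 nM
compound 3 `O=C(C1CCOCC1)N1CCc2nc(C#Cc3ccccc3)sc2C1` gives only the assay limit > 10000 nM

Compound 3 therefore stands at the weak end of what this assay can report: no number, only a limit. The same holds for compound 2, so that two of the three measurements sit at the limit of > 10000 nM in this assay, at which 2 of the 3 values shown sit. Only compound 1, with the small cyclopropyl on the carbonyl carbon, gives a real number.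

The next step leads to compound 4 `O=C(c1cccc(Cl)c1)N1CCc2nc(C#Cc3ccccc3)sc2C1`, and the change is 3-chlorophenyl in place of oxan-4-yl on a carbonyl carbon. Among the compounds with values here, two measured steps bear on this position. Replacing cyclopropyl with a six-membered saturated ring gave an at least 34-fold higher number from compound 1 to compound 2 (1.53 log units; beyond the scatter) and likewise an at least 34-fold higher number from compound 1 to compound 3 (1.53 log units; beyond the scatter). Between the two saturated six-membered rings the comparison is a step that the two limits leave unreadable from compound 2 to compound 3. None of these steps involves an aromatic ring on the carbonyl carbon, so the outcome for 3-chlorophenyl is not anchored by any measured pair; both six-membered saturated rings lost activity, while a flat aromatic ring is a different kind of group.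

Compound 4 is therefore estimated at 1500 nM, with a range from 200 nM to 10000 nM. Relative to compound 3 this estimate means an at least 6.6-fold lower number from compound 3 to compound 4 (0.82 log units; beyond the scatter), with the step expected to be uncertain in size.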

Compound 4, half-maximal inhibitory concentration: > 10000 nM
Compound 4: only a limit was reported; the forecaster's own chance of this, stated with the estimate: 40%; at least 6.6-fold (0.82 log units) between middle value and limit.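

The aromatic 3-chlorophenyl on the carbonyl carbon does no better than the saturated rings: in this assay the change shows an at least 34-fold higher number from compound 1 to compound 4 (1.53 log units; beyond the scatter) and so the loss seen with cyclohexyl and oxan-4-yl is not confined to saturated six-membered rings. The steps among compound 2, compound 3 and compound 4 cannot be read, as each of these compounds has only a limit, so no order among their three groups can be drawn. Of the four compounds shown, only compound 1, with cyclopropyl, gives a real number, and all three compounds with a six-membered ring on the carbonyl carbon end at the same reporting limit: the limit of > 10000 nM in this assay, at which 3 of the 4 values shown sit.

Going by these compounds, it stays open whether a cyclobutyl or cyclopentyl ring, a plain methyl, or a phenyl without the chlorine would give a real number at this position. Also open is whether the activity fades gradually from cyclopropyl to the six-membered rings or disappears at once, since the compounds shown offer nothing in between.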